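A few compounds are considered here, and "the series" means these few. Any claim that something is new, unique, unknown or untested is made for them only; others in the source may bear on it.

Compound 3 `O=c1c(OCc2cccc([N+](=O)[O-])c2)c(-c2ccccc2)oc2cc(O)cc(O)c12` shares its core with compound 1 `O=c1c(OCc2ccccc2Br)c(-c2ccccc2)oc2cc(O)cc(O)c12` and compound 2 `N#Cc1cccc(COc2c(-c3ccccc3)oc3cc(O)cc(O)c3c2=O)c1`, and in an ADME assay on Huh-5-2 cells (Homo sapiens) for cytotoxicity, read by WST assay, with a stated time of 3 days (on this read-out lower numbers stand for higher toxicity in this test and higher numbers for lower toxicity in this test), compound 3 gives 31000 nM. This is the highest of the three numbers: compound 2 gives 21000 nM and compound 1 gives 12000 nM, so compound 3 lies within the scatter of compound 2, while against compound 1 the gap is beyond it, as seen in a 2.6-fold higher number from compound 1 to compound 3 (0.41 log units; beyond the scatter).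

Compound 4 `Cc1cccc(COc2c(-c3ccccc3)oc3cc(O)cc(O)c3c2=O)c1` differs from compound 3 by methyl in place of nitro on an aromatic carbon. For the measured compounds named here, the only measured step at this aromatic carbon is a 1.5-fold higher number from compound 2 to compound 3 (0.17 log units; within the scatter), which stays within the scatter; the step of a 2.6-fold higher number from compound 1 to compound 3 (0.41 log units; beyond the scatter) also swaps 2-bromophenyl for 3-nitrophenyl and so bears only loosely. With two substituents at this position giving numbers within the scatter of each other, no step beyond the scatter is expected for a third, though a small drift back toward the numbers of compound 2 and compound 1 is possible. Compound 4 is therefore estimated at 24000 nM in this assay, range 10000 nM to 55000 nM, an expected step of a 1.3-fold lower number from compound 3 to compound 4 (0.11 log units; within the scatter).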

Compound 4, half-maximal cytotoxic concentration: 29000 nM
Compound 4: the middle estimate sits 1.2-fold (0.08 log units) below what was measured, within the range that was stated.
By their numbers in this assay, from the lowest: compounds 1, 2, 4 and 3 (each within the scatter of the next, the first and the last beyond it).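

In this assay, methyl on this aromatic carbon cannot be told apart from nitro (a 1.1-fold lower number from compound 3 to compound 4 (0.03 log units; within the scatter)) or from cyano (a 1.4-fold higher number from compound 2 to compound 4 (0.14 log units; within the scatter)), so a one-carbon group with no hydrogen-bond acceptors reads like both earlier groups. Only the comparison with the 2-bromophenyl compound clears the scatter (a 2.4-fold higher number from compound 1 to compound 4 (0.38 log units; beyond the scatter)), and that step changes both the substituent and its place on the ring, so it isolates neither. Nothing measured here bears on why these three substituents read alike.

From the compounds shown here alone, whether the gap to compound 1 comes from bromine itself or from where it sits on the ring remains open. Also open, going by these compounds, is whether an amine, a carboxylic acid or a longer alkyl chain on this aromatic carbon would move the number beyond the scatter.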